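Chain homologation at the anilide of a bis-sulfonamide series

The source may report more compounds than this note shows. Statements on the series, on what has been measured and on what is new or still open speak of the compounds shown alone.

Compound 1 `COc1ccc(S(=O)(=O)N(CC(N)=O)c2ccc(N(CC(N)=O)S(=O)(=O)c3ccc(NC(C)=O)cc3)c3ccccc23)cc1`: in a functional assay on cells (Peritoneal macrophage, Mus musculus) for cytotoxicity, with a stated time of 24 h (a higher number here means that more compound is tolerated, a lower number that less compound is tolerated), compound 1 gives > 50000 nM, a limit of the assay.
Compound 2 `CCCC(=O)Nc1ccc(S(=O)(=O)N(CC(N)=O)c2ccc(N(CC(N)=O)S(=O)(=O)c3ccc(OC)cc3)c3ccccc23)cc1`: in this assay compound 2 gives > 100000 nM, also a limit of the assay.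

Compound 2 therefore stands only at a limit in this assay. The step that the two limits leave unreadable from compound 1 to compound 2 cannot be read, as it runs between the limit of > 50000 nM in this assay, at which 1 of the 2 values shown sits, and (the limit of > 100000 nM in this assay, at which 1 of the 2 values shown sits). Compound 3 `CCCCC(=O)Nc1ccc(S(=O)(=O)N(CC(N)=O)c2ccc(N(CC(N)=O)S(=O)(=O)c3ccc(OC)cc3)c3ccccc23)cc1` carries the change (methyl in place of hydrogen on a saturated chain carbon, three bonds along the chain from a carbonyl carbon). No readable measured step bears on this change, so no direction can be drawn from the data. Compound 3 is expected to remain at a limit, with a number no higher from compound 2 to compound 3 (the limit leaves the size open) estimated as no step beyond the scatter. The estimate for compound 3 is 100000 nM, range 50000 nM to 300000 nM.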

Compound 3, half-maximal cytotoxic concentration: > 100000 nM
Compound 3 gave a limit, no number (the forecaster's own chance of this, stated with the estimate: 85%); the middle value sits exactly at the limit.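

Compound 3 also sits at a limit of the assay, > 100000 nM, so its steps from compound 1 and compound 2 cannot be read. The compounds shown leave open whether chain length changes tolerated concentration at all in this assay.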